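The source may hold more compounds than are shown below. What is called first, only, known or untested is meant among the compounds shown, and "the series" means these compounds.

Going by the values given here, compound 1 `O=C1c2c[n+]([O-])c3ccccc3c2C(=O)c2c1c1ccccc1n2Cc1cn([C@H]2C[C@H](O)[C@@H](CO)O2)nn1` is the stronger of the two compounds measured so far. In a functional assay on MDA-MB-231 cells (Homo sapiens) for cytotoxicity, read by MTT assay, with a stated time of 72 h (on this read-out higher numbers stand for weaker inhibition and lower numbers for stronger inhibition), compound 1 gives 580 nM, while compound 2 `O=C1c2c[n+]([O-])c3ccccc3c2C(=O)c2c1c1ccccc1n2Cc1cn(CC(O)CO)nn1` gives 1290 nM; that step is a 2.2-fold higher number from compound 1 to compound 2 (0.35 log units; beyond the scatter). Compound 3 `O=C1c2c[n+]([O-])c3ccccc3c2C(=O)c2c1c1ccccc1n2Cc1cn([C@@H]2C[C@H](O)[C@@H](CO)O2)nn1` is the next compound. Compared with compound 1, (the two compounds have the same atoms and bonds and differ only in configuration as drawn: 1 of 3 stereo elements differ; a stereocentre at a saturated ring carbon is drawn R in compound 1 and S in compound 3). Among the compounds with values here, no measured step concerns a change of configuration alone, and the single step seen, a swap of the whole ring for a chain, was modest. The expected step is a 1.6-fold higher number from compound 1 to compound 3 (0.19 log units; within the scatter), a small loss, though the direction is uncertain. Compound 3 is estimated at 900 nM, ranging from 400 nM to 2200 nM.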

Compound 3, half-maximal inhibitory concentration in the MDA-MB-231 assay: 130 nM
For compound 3 the middle estimate is 6.9-fold (0.84 log units) above the measured one; measured number outside the range, below it.
By their numbers in the MDA-MB-231 assay, from the lowest: compound 3; then compound 1; then compound 2.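

In the MDA-MB-231 assay, changing one stereocentre on the ring gives a 4.5-fold lower number from compound 1 to compound 3 (0.65 log units; beyond the scatter), and the 4-hydroxy-5-(hydroxymethyl)oxolan-2-yl group as drawn in compound 3 does better than 2,3-dihydroxypropyl, with a 9.9-fold lower number from compound 2 to compound 3 (1.00 log units; beyond the scatter); the first of these steps rests on configuration alone, as shown by this: the fact that compounds 1 and 3 differ only in the configuration as drawn. In a physicochemical assay for solubility, read by HPLC, with a stated time of 24 h (a higher number here means a more soluble compound, a lower number a less soluble compound), compound 1 gives > 5000 ug/mL, which is a limit of the assay and not a number. In the physicochemical assay compound 3 gives > 5000 ug/mL, again a limit, so the step between the two cannot be read: the limit of > 5000 ug/mL in the physicochemical assay, at which 2 of the 2 values shown sit.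

From the compounds shown here alone, the effect of changing the other two stereocentres remains open. So does whether an amine or a carboxylic acid in place of the hydroxymethyl would keep the number seen for compound 3.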